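The source may report more compounds than this note shows. Statements on the series, on what has been measured and on what is new or still open speak of the compounds shown alone.

Measured so far in a functional assay on HL-60 cells (Homo sapiens) for cytotoxicity, read by MTT assay, with a stated time of 72 h; a higher number here means a weaker inhibitor, a lower number a stronger inhibitor:
- compound 1, `COc1ccc(C(=O)O[C@H]2CC(C)=C[C@H](O)[C@@]3(C)[C@@H](OC(C)=O)C[C@@](O)(C(C)C)[C@H]23)cc1`: 23000 nM
- compound 2, `COc1ccc(C(=O)O[C@H]2CC(C)=C[C@@H](OC(C)=O)[C@@]3(C)[C@@H](OC(C)=O)C[C@@](O)(C(C)C)[C@H]23)cc1`: 83500 nM

Two compounds carry numbers. Compound 2 stands at the higher of the two: its number lies well beyond the scatter from that of compound 1, so compound 2 is the weaker inhibitor of the pair on what is shown. The esters and the shared core are otherwise alike.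

The next compound is compound 3, `COc1ccc(C(=O)O[C@H]2CC(C)=C[C@@H](O)[C@@]3(C)[C@@H](OC(C)=O)C[C@@](O)(C(C)C)[C@H]23)cc1`, not yet measured. Relative to compound 2 the change is hydrogen in place of acetyl on an oxygen on a saturated carbon. It is the removal of one acetyl, nothing more, and the two compounds agree in every stereocentre.

Among the compounds with values here, no step between two measured compounds is available, so the size of this step in this assay is not anchored by a precedent. Within the data shown here, the only guide is that compound 2, the sole compound carrying acetyl at that oxygen, gives the highest number, which suggests a move toward the lower number of compound 1 rather than away from it. A modest to moderate drop is expected, a 2.8-fold lower number from compound 2 to compound 3 (0.44 log units; beyond the scatter), though a result within the scatter of compound 2 cannot be ruled out. Compound 3 is estimated at 30000 nM, with a range from 12000 nM to 80000 nM.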

Compound 3, half-maximal inhibitory concentration: 24000 nM
Beside the measured number, compound 3's estimate is 1.3-fold (0.10 log units) above it, and the stated range covers the measured number.
By their numbers in this assay, from the lowest: compounds 1 and 3 (each within the scatter of the next); then compound 2.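

In this assay, the first step read at a single place gives a 3.5-fold lower number from compound 2 to compound 3 (0.54 log units; beyond the scatter), so acetoxy to hydroxy on an oxygen on a saturated carbon registers beyond the scatter, and the acetyl on this oxygen is shown to matter for the number in this series. With the hydroxy in place, the drawn configuration at that saturated ring carbon shows no readable effect, since the step is a 1.0-fold higher number from compound 1 to compound 3 (0.02 log units; within the scatter), which lies within the scatter. This comparison is a clean test of configuration alone, and it rests on one fact: the fact that compounds 1 and 3 differ only in the configuration as drawn.

The compounds shown leave open how an acetoxy group reads in the configuration of compound 1, so it remains unknown whether configuration at this carbon is also without effect when the oxygen carries acetyl. They also leave open how other groups at this oxygen would read, such as a propionyl ester, a methyl ether or an amine in place of the oxygen, and so whether the step seen here is specific to acetyl.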